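Trading Cyclopentyl for Isopropyl on the Core Nitrogen

The compounds below may be only part of what the source reports. "The series", "measured", "known", "first", "only" and "open" are said of these compounds alone.

Compound 1 `COC(CCn1cnc2c(NCc3ccc(C(=O)Nc4ccccc4N)cc3)nc(Cl)nc21)OC` gives 51.2%.
Compound 2 `Nc1ccccc1NC(=O)/C=C/c1ccc(COCNc2nc(Nc3cccc(Cl)c3)c3ncn(C4CCCC4)c3n2)cc1` gives 46.1%.

Both numbers come from a functional assay on NCI-H460 cells (Homo sapiens) for antiproliferative activity, read by CCK-8 assay, with a stated time of 72 h, tested at 8 uM; on this read-out higher numbers stand for a stronger effect at the one concentration tested and lower numbers for a weaker effect. Compound 2 holds the lowest of the two numbers, yet compound 1 sits within the scatter of it, so the two cannot be told apart. Compound 3 `CC(C)n1cnc2c(Nc3cccc(Cl)c3)nc(NCOCc3ccc(/C=C/C(=O)Nc4ccccc4N)cc3)nc21` differs from compound 2 in one place: isopropyl in place of cyclopentyl on an aromatic nitrogen. Among the measured compounds shown here, no measured pair shows this exchange, so its size is unknown, and the expectation is a step no larger than the scatter, in no clear direction. Compound 3 is expected to give about 44% in this assay, between 28% and 60%. The expected step is a number 2.1 percentage points lower from compound 2 to compound 3 (within the scatter).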

Compound 3, a percentage reported as inhibition, at one concentration (the size of the read-out at that concentration, not a potency): 61.1%
The estimate for compound 3 lay 17.1 percentage points below the measured number, and the stated range ends below it.
By their numbers in this assay, from the lowest: compounds 2, 1 and 3 (each within the scatter of the next, the first and the last beyond it).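

Exchanging cyclopentyl for isopropyl on this aromatic nitrogen gives, in this assay, a number 15 percentage points higher from compound 2 to compound 3 (beyond the scatter), so the group at this position does change the read-out. Of these two groups, the one with fewer heavy atoms and no ring gives the larger effect at the one concentration tested. Nothing available here gives a reason for this rise.

Two groups at one position make no trend. Methyl, a longer carbon chain or a chain ending in an amine on the same nitrogen could move the number either way.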